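Larger Pyridine Amide in Place of a Methylpyrazole

The source may report more compounds than this note shows. Statements on the series, on what has been measured and on what is new or still open speak of the compounds shown alone.

Compound 1 `Cn1cc(-c2cnc(NCc3c(F)ccc4c3CCO4)c3cn[nH]c(=O)c23)cn1`, compound 2 `CN(c1ncco1)c1cnc(NCc2c(F)ccc3c2CCO3)n2cnnc12` and compound 3 `Cc1ncccc1-c1cnc(NCc2c(F)ccc3c2CCO3)c2ncc(=O)[nH]c12` were all tested in a physicochemical assay for solubility, read by LC-MS, in phosphate buffer, with a stated time of 24 h, at pH 7.4; a lower number here means a less soluble compound, a higher number a more soluble compound. Compound 1 gives 1000 nM, the lowest of the three numbers. Compound 3 gives 29000 nM and compound 2 gives 67000 nM; both stand above compound 1 by gaps beyond the usual scatter. Compound 4 `CNC(=O)c1ccc(-c2cnc(NCc3c(F)ccc4c3CCO4)c3cn[nH]c(=O)c23)c(C)n1` has not yet been measured in this assay. It differs from compound 1 in one place: 2-methyl-6-(methylcarbamoyl)pyridin-3-yl in place of 1-methyl-1H-pyrazol-4-yl on an aromatic carbon. Among the compounds with values here, no measured pair shows this change, so its step size is unknown. The entering group carries one hydrogen-bond donor, and compound 3, which also bears a methylpyridinyl group, sits well above compound 1; in this assay compound 3 gives 29000 nM. The step is expected to be a modest rise, a 4.0-fold higher number from compound 1 to compound 4 (0.60 log units; beyond the scatter). Compound 4 is estimated at 4000 nM, within 1000 nM to 20000 nM.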

Compound 4, solubility: 19000 nM
Estimate against measurement, compound 4: 4.8-fold (0.68 log units) below; measured number inside the range.
By their numbers in this assay, from the lowest: compound 1; then compounds 4 and 3 (each within the scatter of the next); then compound 2.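

In this assay, within the data shown here, 2-methyl-6-(methylcarbamoyl)pyridin-3-yl in place of 1-methyl-1H-pyrazol-4-yl on this aromatic carbon gives a 19-fold higher number from compound 1 to compound 4 (1.28 log units; beyond the scatter), the first step that can be read at this position. With the rest of the molecule unchanged, the number clearly depends on the group placed here, and the larger entering group does not hold it down. No supporting measurement bears on this result.

The change swaps the ring and adds the methyl and the methylcarbamoyl group all at once, and the compounds shown do not separate these parts. A plain 2-methylpyridin-3-yl group, or a carboxylic acid in place of the methylcarbamoyl group, would begin to tell them apart.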